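The compounds below may be only part of what the source reports. "The series", "measured", "known", "first", "only" and "open" are said of these compounds alone.

In a functional assay on MCF7 cells (Homo sapiens) for inhibition, read by sulforhodamine B assay, with a stated time of 48 h (on this read-out higher numbers stand for weaker inhibition of growth and lower numbers for stronger inhibition of growth), compound 1 (`O=C(NNC(=O)c1ccc2[nH]c(-c3ccc([N+](=O)[O-])o3)nc2c1)c1ccccc1`) gives 62.5 ug/mL. Compound 3 (`O=C(NNC(=O)c1cc2ccccc2cc1O)c1ccc2[nH]c(-c3ccc([N+](=O)[O-])s3)nc2c1`) gives 62.5 ug/mL, level with compound 1 at the digits reported. Compound 2 (`COc1cc(C(=O)NNC(=O)c2ccc3[nH]c(-c4ccc([N+](=O)[O-])s4)nc3c2)cc(OC)c1OC`) gives 31.3 ug/mL, which is still within the usual scatter of compound 1. The numbers therefore do not separate the three compounds.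

Compound 4 (`COc1ccc(C(=O)NNC(=O)c2ccc3[nH]c(-c4ccc([N+](=O)[O-])o4)nc3c2)cc1OC`) has not yet been measured in this assay. It keeps the core of compound 1 and differs at one place, with 3,4-dimethoxyphenyl in place of phenyl on a carbonyl carbon. Within the data shown here, no measured pair isolates this change, so the data offer no direct guide to its size. With compound 1 at 62.5 ug/mL and compound 2 at 31.3 ug/mL lying within the scatter of each other, no step beyond the scatter is expected in this assay, in either direction. The expected change is a 1.3-fold lower number from compound 1 to compound 4 (0.10 log units; within the scatter), which stays within the scatter. Compound 4 is estimated at 50 ug/mL, with an expected range of 20 ug/mL to 125 ug/mL.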

Compound 4, concentration for 50% growth inhibition: 31.3 ug/mL
Compound 4: the middle estimate sits 1.6-fold (0.20 log units) above what was measured, and the stated range covers the measured number.
By their numbers in this assay, from the lowest: compounds 2, 4, 1 and 3 (each within the scatter of the next).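

Among these compounds, this is the first pair of measured compounds that isolates a change at this place: in this assay, 3,4-dimethoxyphenyl in place of phenyl on a carbonyl carbon gives a 2.0-fold lower number from compound 1 to compound 4 (0.30 log units; within the scatter). The step lies within the scatter, so the read-out does not separate the two compounds, even though the entering group is larger than phenyl and brings hydrogen-bond acceptors that phenyl lacks. Nothing available explains the size of this step.

A single pair cannot show whether other groups at this place would behave in the same way. From the compounds shown here alone, it remains open whether an amine, a carboxylic acid or a longer chain on this carbonyl carbon would produce a step beyond the scatter, in either direction.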